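The source may hold more compounds than are shown below. What is called first, only, known or untested is meant among the compounds shown, and "the series" means these compounds.

Measured so far in an ADME assay on Raji cells (Homo sapiens) for cytotoxicity, with a stated time of 72 h; a higher number here means that more compound is needed for the effect, a lower number that less compound is needed:
compound 1 `CC(=O)c1ccc(NC(=O)Nc2cc(C)nc3ccccc23)cc1`: > 25000 nM (a limit of the assay)
compound 2 `Cc1cc(NC(=O)Nc2ccccc2N)c2ccccc2n1`: > 25000 nM (a limit of the assay)

Compound 2 has no number in this assay: compound 2 sits at > 25000 nM, which is a limit. Among the measured compounds shown here, the series so far consists only of the limit of > 25000 nM in this assay, at which 2 of the 2 values shown sit.

Compound 3 `Cc1ccc(NC(=O)Nc2cc(C)nc3ccccc23)cc1` carries 4-methylphenyl in place of 2-aminophenyl on an amide-type nitrogen.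

No measured step sizes this change, so no step beyond the scatter is expected in this assay. The expectation rests on compound 1, which also stands at a limit, > 25000 nM. The estimated step of a number no higher from compound 2 to compound 3 (the limit leaves the size open) is expected to stay within the scatter. Another limit is the likely report. For compound 3 the estimate is 25000 nM, with an expected range of 12000 nM to 50000 nM.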

Compound 3, half-maximal effective concentration: > 25000 nM
Compound 3 ended at the assay's limit; the forecaster's own chance of this, stated with the estimate: 80%; the middle value lies on the limit itself.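

In this assay compound 3 gives > 25000 nM, a limit of the assay. The steps to compound 3 from compound 1 and compound 2, both also at limits, cannot be read. How these three compounds compare in this assay stays open, with the series resting on one value: the limit of > 25000 nM in this assay, at which 3 of the 3 values shown sit.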